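A few compounds are considered here, and "the series" means these few. Any claim that something is new, unique, unknown or untested is made for them only; others in the source may bear on it.

Measured so far in a functional assay on B16-F10 cells (Mus musculus) for antiproliferative activity, read by MTT assay, with a stated time of 48 h; on this read-out higher numbers stand for weaker inhibition and lower numbers for stronger inhibition:
- compound 1 `COc1ccc(/C=C/c2cc(OC)cc(OC)c2/C=C/C(=O)c2ccc(N)cc2)cc1` gives 2.8 ug/mL
- compound 2 `COc1ccc(/C=C/c2cc(OC)cc(OC)c2/C=C/C(=O)c2ccc(F)cc2)cc1` gives 5.3 ug/mL

Within the data shown here, compound 2 shares the shared core with compound 1, and these are the only two numbers available. They lie within the scatter of each other, so compound 2 cannot be ranked apart from compound 1.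

The next entry is compound 3 `COc1ccc(/C=C/c2cc(OC)cc(OC)c2/C=C/C(=O)c2ccc(C)cc2C)cc1`. It differs from compound 2 by 2,4-dimethylphenyl in place of 4-fluorophenyl on a carbonyl carbon.

Among the measured compounds shown here, one measured step bears on this change, fluoro in place of amino on an aromatic carbon, and it is a 1.9-fold higher number from compound 1 to compound 2 (0.28 log units; within the scatter). For the measured compounds named here, no measured compound carries the 2,4-dimethylphenyl group, so this single step is thin guidance. No shift beyond the scatter is expected in this assay, and no direction is favoured.

The expected size of the change is a 1.1-fold lower number from compound 2 to compound 3 (0.03 log units; within the scatter). For compound 3 the estimated value is 5 ug/mL, with an expected range of 2 ug/mL to 12 ug/mL.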

Compound 3, half-maximal inhibitory concentration: 4 ug/mL
For compound 3 the middle estimate is 1.3-fold (0.10 log units) above the measured one; low and high end bracket the measured number.
By their numbers in this assay, from the lowest: compounds 1, 3 and 2 (each within the scatter of the next).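

Working notes on the group on the carbonyl carbon: in this assay, 2,4-dimethylphenyl in place of 4-fluorophenyl gives a 1.3-fold lower number from compound 2 to compound 3 (0.12 log units; within the scatter) and 2,4-dimethylphenyl in place of 4-aminophenyl gives a 1.4-fold higher number from compound 1 to compound 3 (0.15 log units; within the scatter), so neither step leaves the scatter. Among these compounds, the earlier pair compared only two singly substituted phenyl groups, whereas this result shows that a phenyl group carrying two methyl groups also produces no separable shift at this position. Nothing at hand bears on the reason for this result.

As far as these compounds go, whether a non-aromatic group such as a morpholine or a longer alkyl chain on the carbonyl carbon would move the number beyond the scatter remains open. So does the effect of a carboxylic acid on the phenyl group, or of replacing the methoxy groups on the shared core.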